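Aryl variation on a shared core: cytotoxicity working notes

The source may report more compounds than this note shows. Statements on the series, on what has been measured and on what is new or still open speak of the compounds shown alone.

Three compounds on one shared core have been run in an ADME assay on RAW264.7 cells (Mus musculus) for cytotoxicity, read by MTT assay, with a stated time of 48 h; on this read-out lower numbers stand for higher toxicity in this test and higher numbers for lower toxicity in this test. Compound 1 `CC(=O)OC[C@H]1O[C@H](OC[C@@H](Cn2cc(CN(c3nc(-c4ccc([N+](=O)[O-])cc4)no3)C3CCCCC3)nn2)OC(C)=O)C=C[C@@H]1OC(C)=O` gives 64.1 ug/mL. Compound 2 `CC(=O)OC[C@H]1O[C@H](OC[C@@H](Cn2cc(CN(c3nc(-c4ccc(C)cc4)no3)C3CCCCC3)nn2)OC(C)=O)C=C[C@@H]1OC(C)=O` gives 45.3 ug/mL, and compound 3 `CC(=O)OC[C@H]1O[C@H](OC[C@@H](Cn2cc(CN(c3nc(-c4cccc(C)c4)no3)C3CCCCC3)nn2)OC(C)=O)C=C[C@@H]1OC(C)=O` gives 46.4 ug/mL. On the numbers shown, compound 3 stands second highest of the three, though all three lie within the scatter of one another: its nearest neighbour is compound 2, by a 1.0-fold higher number from compound 2 to compound 3 (0.01 log units; within the scatter), and its furthest is compound 1, by a 1.4-fold lower number from compound 1 to compound 3 (0.14 log units; within the scatter). The remaining step, a 1.4-fold lower number from compound 1 to compound 2 (0.15 log units; within the scatter), is also within the scatter, so none of the aryl variants measured so far moves the read-out beyond repeat noise.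

Compound 4 `CC(=O)OC[C@H]1O[C@H](OC[C@@H](Cn2cc(CN(c3nc(-c4ccc(C(F)(F)F)cc4)no3)C3CCCCC3)nn2)OC(C)=O)C=C[C@@H]1OC(C)=O` is not yet measured. It differs from compound 3 by 4-(trifluoromethyl)phenyl in place of 3-methylphenyl on an aromatic carbon. The measured steps that bear on this change are the two that vary the same aryl group, a 1.4-fold lower number from compound 1 to compound 3 (0.14 log units; within the scatter) and a 1.0-fold higher number from compound 2 to compound 3 (0.01 log units; within the scatter), both within the scatter. No step beyond the scatter is therefore expected in this assay. The expected step is a 1.1-fold higher number from compound 3 to compound 4 (0.03 log units; within the scatter). In this assay compound 4 is estimated at 50 ug/mL, with an expected range from 30 ug/mL to 85 ug/mL.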

Compound 4, half-maximal cytotoxic concentration: 64.1 ug/mL
Compound 4: the middle estimate sits 1.3-fold (0.11 log units) below what was measured; low and high end bracket the measured number.
By their numbers in this assay, from the lowest: compounds 2, 3, 1 and 4 (each within the scatter of the next).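

In this assay, 4-(trifluoromethyl)phenyl is the first group shown at this place that carries fluorine, and compound 4 lies within the scatter of all three earlier compounds (a 1.4-fold higher number from compound 3 to compound 4 (0.14 log units; within the scatter); a 1.4-fold higher number from compound 2 to compound 4 (0.15 log units; within the scatter); no change at the digits printed from compound 1 to compound 4 (within the scatter)). Across these four compounds, the aryl groups on this aromatic carbon, between two ring nitrogen atoms, give no step beyond the scatter, and none of the four goes against this. Nothing shown offers an explanation for this flat picture.

On these data alone, it remains open whether an amine, a carboxylic acid or a longer alkyl chain on the phenyl ring would carry the read-out beyond the scatter. The compounds shown also leave open whether the picture holds when another place on the shared core is varied.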